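The source may hold more compounds than are shown below. What is called first, only, known or untested is meant among the compounds shown, and "the series" means these compounds.

Compound 1, `O=c1ccn(CCN2CCCCC2)c(CO)c1O`: 0.019
Compound 2, `Cn1cc(O)c(=O)cc1CN1CCCCC1`: 0.64
Compound 3, `CCc1c(O)c(=O)ccn1CC`: 0.257

In a physicochemical assay for lipophilicity (a higher number here means a more lipophilic compound, a lower number a more polar compound), compound 3 gives 0.257, the second highest of the three numbers. Its nearest neighbour is compound 1, which gives 0.019, a number lower by an amount within the scatter, so the two cannot be put in order. The furthest is compound 2, which gives 0.64, a number beyond the scatter above compound 3. No two of these compounds differ in a single place, so no individual structural step can be read off from the measured set.

Compound 4 `CCc1c(O)c(=O)ccn1CCN(C)C` differs from compound 3 by one change: dimethylamino in place of hydrogen on a saturated chain carbon, two bonds along the chain from an aromatic nitrogen. Among the compounds with values here, no measured pair shows what this change does in this assay. Within the data shown here, the only indirect guide is the other compound whose chain carries a second nitrogen, compound 1, which gives 0.019, the lowest of the three numbers, although it differs from compound 3 in more than one place. On that basis the step from compound 3 to compound 4 is expected to be a number 0.26 log units lower from compound 3 to compound 4 (within the scatter), downward but not clearly beyond the scatter. Compound 4 is therefore estimated at 0, with a range from -0.5 to 0.5.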

Compound 4, partition coefficient: -0.114
Estimate against measurement, compound 4: 0.11 log units above; low and high end bracket the measured number.
By their numbers in this assay, from the lowest: compounds 4, 1 and 3 (each within the scatter of the next, the first and the last beyond it); then compound 2.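

In this assay, dimethylamino in place of hydrogen on a saturated chain carbon, two bonds along the chain from an aromatic nitrogen, gives a number 0.37 log units lower from compound 3 to compound 4 (beyond the scatter), a modest step but the first in the set that isolates one change. Until now, no pair of compounds differing in one place had shown what happens at this position, and this pair, which can also be read as ethyl to 2-(dimethylamino)ethyl, fixes both the direction and the size of the change on the shared core. Within the data shown here, it establishes only that for this one pair, however, and no measurement at hand offers an explanation for the step.

The compounds shown leave open whether a morpholine or a carboxylic acid at the end of the same chain would move the number in this assay in the same direction, and by a similar amount. They also leave open whether dimethylamino on a longer chain would repeat this step, and whether the change would carry over to a different substitution elsewhere on the core.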